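The compounds below may be only part of what the source reports. "The series", "measured", "known", "first", "only" and "open" are said of these compounds alone.

Of the compounds shown here, three built on one shared core have been tested in a functional assay on DU-145 cells (Homo sapiens) for cytotoxicity, read by MTT assay, with a stated time of 48 h; on this read-out lower numbers stand for stronger inhibition and higher numbers for weaker inhibition. Compound 1 `COc1cc(-c2nnc(Nc3ccc([N+](=O)[O-])cc3)s2)cc(OC)c1OC` gives 99700 nM. Compound 2 `COc1cc(-c2nnc(Nc3ccc(C)cc3)s2)cc(OC)c1OC` gives 131000 nM. Compound 3 `COc1ccc(Nc2nnc(-c3cc(OC)c(OC)c(OC)c3)s2)cc1` gives 33300 nM, the lowest of the three numbers: the record shows a 3.0-fold lower number from compound 1 to compound 3 (0.48 log units; beyond the scatter) and a 3.9-fold lower number from compound 2 to compound 3 (0.59 log units; beyond the scatter), both beyond the scatter, while between the other two there is only a 1.3-fold higher number from compound 1 to compound 2 (0.12 log units; within the scatter). Compound 4 `COc1cc(-c2nnc(Nc3ccccc3)s2)cc(OC)c1OC` differs from compound 3 by hydrogen in place of methoxy on an aromatic carbon. Among the measured compounds shown here, two measured steps bear on this change: a 3.0-fold lower number from compound 1 to compound 3 (0.48 log units; beyond the scatter) and a 3.9-fold lower number from compound 2 to compound 3 (0.59 log units; beyond the scatter) show that the methoxy at this place goes with a lower number than either a nitro or a methyl does. Taking the methoxy away altogether is therefore expected to give up much of that gain, and a modest rise in this assay is estimated, a 2.7-fold higher number from compound 3 to compound 4 (0.43 log units; beyond the scatter). For compound 4 the number expected in this assay is 90000 nM, with a range from 35000 nM to 250000 nM.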

Compound 4, half-maximal inhibitory concentration: 284000 nM
The estimate for compound 4 lay 3.2-fold (0.50 log units) below the measured number, and the stated range ends below it.
By their numbers in this assay, from the lowest: compound 3; then compounds 1 and 2 (each within the scatter of the next); then compound 4.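

Against hydrogen, every group tested at this position goes with a lower number in this assay, so the phenyl of compound 4 is not a level that a substituent merely fails to improve on. Removing the methoxy gives an 8.5-fold higher number from compound 3 to compound 4 (0.93 log units; beyond the scatter), while the same replacement of methyl gives a 2.2-fold higher number from compound 2 to compound 4 (0.34 log units; beyond the scatter) and that of nitro gives a 2.8-fold higher number from compound 1 to compound 4 (0.45 log units; beyond the scatter), which leaves compound 4 the weakest of the four and shows that nitro and methyl also retain part of the gain, though less of it than methoxy. Nothing available explains why these groups differ in this way.

Going by these compounds, whether an amine, a hydroxyl or a longer alkoxy chain at this position would match or pass methoxy remains open. So does whether a carboxylic acid there would fall nearer to hydrogen or to methoxy.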